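This account rests on a few compounds, and the source may have more. Where it says the series, first, only, none or still open, it means among the compounds named here.

Working notes on the shared core of compound 1 `CCCCc1ccc(NS(=O)(=O)c2ccc(N3CCNC3=O)cc2)cc1`. In a functional assay on MCF7 cells (Homo sapiens) for antiproliferative activity, read by sulforhodamine B assay, with a stated time of 48 h (on this read-out lower numbers stand for stronger inhibition and higher numbers for weaker inhibition), compound 1 gives 770 nM. Compound 2 `COc1ccc(NS(=O)(=O)c2ccc(N3CCNC3=O)cc2)cc1OC` gives 610 nM in this assay; the two values lie within the scatter of each other, so compound 1 cannot be ranked against compound 2 on these numbers. Compound 3 `CCCCCc1ccc(NS(=O)(=O)c2ccc(N3CCNC3=O)cc2)cc1` differs from compound 1 by methyl in place of hydrogen on a saturated chain carbon, four bonds along the chain from an aromatic carbon. Within the data shown here, no measured pair shows a step of this kind, so there is nothing to anchor its size. For compound 3 the expected step is a 1.1-fold lower number from compound 1 to compound 3 (0.04 log units; within the scatter), none beyond the scatter. Compound 3 is estimated at 700 nM, within 350 nM to 1400 nM.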

Compound 3, half-maximal inhibitory concentration: > 1000 nM
Compound 3: a limit, no number (the forecaster's own chance of this, stated with the estimate: 3%); middle value at least 1.4-fold (0.15 log units) from the limit.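

Compound 3 gives > 1000 nM in this assay, which is a limit of the assay and not a number. Methyl in place of hydrogen on a saturated chain carbon, four bonds along the chain from an aromatic carbon, gives an at least 1.2-fold higher number from compound 1 to compound 3 (0.11 log units; that floor lies within the scatter). This is the first step read at this position, and only its floor is known, so the size of the change stays unfixed: the limit of > 1000 nM in this assay, at which 1 of the 3 values shown sits.

The compounds shown leave open how a shorter propyl chain or a longer hexyl chain would read here. They also leave open whether an amine or a carboxylic acid at the chain end would give a number rather than a limit.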